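This account rests on a few compounds, and the source may have more. Where it says the series, first, only, none or still open, it means among the compounds named here.

Measured so far in a functional assay on HeLa cells (Homo sapiens) for antiproliferative activity, read by CCK-8 assay, with a stated time of 72 h; on this read-out higher numbers stand for weaker inhibition and lower numbers for stronger inhibition:

compound 1 `Cc1cc(Nc2cc(N3CCN(C)CC3)nc(Nc3ccc(Cl)cc3)n2)n[nH]1`: 619 nM
compound 2 `Cc1cc(Nc2cc(N3CCN(C)CC3)nc(Nc3ccc(C#N)cc3)n2)n[nH]1`: 331 nM

Going by the values given here, compound 2, at 331 nM, lies within the usual scatter of compound 1, its only neighbour on this scale, so the two cannot be ranked. The next compound, compound 3 `COc1ccc(Nc2nc(Nc3cc(C)[nH]n3)cc(N3CCN(C)CC3)n2)cc1`, has methoxy in place of cyano on an aromatic carbon, para to a large group: methoxy in place of cyano on an aromatic carbon. Among the compounds with values here, only one measured step bears on this change, and it falls on the same carbon: a 1.9-fold lower number from compound 1 to compound 2 (0.27 log units; within the scatter), with cyano in place of chloro. That step stayed within the scatter. Within the data shown here, it is a single step, however, and no measured compound yet carries methoxy, so the evidence is thin. No step beyond the scatter is therefore expected in this assay, and no direction can be firmly called. The estimate amounts to a 1.3-fold higher number from compound 2 to compound 3 (0.10 log units; within the scatter). For compound 3 the estimated value is 420 nM, with an expected range from 160 nM to 1100 nM.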

Compound 3, half-maximal inhibitory concentration: 867 nM
Compound 3: middle estimate off by 2.1-fold (0.31 log units), on the low side; low and high end bracket the measured number.
By their numbers in this assay, from the lowest: compounds 2, 1 and 3 (each within the scatter of the next, the first and the last beyond it).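

In this assay this carbon, para to a large group, now gives its first step beyond the scatter: methoxy in place of cyano produces a 2.6-fold higher number from compound 2 to compound 3 (0.42 log units; beyond the scatter) and so separates the two groups on this scale, though only modestly. Methoxy in place of chloro on the same carbon gives a 1.4-fold higher number from compound 1 to compound 3 (0.15 log units; within the scatter) and stays within the scatter, so compound 1 and compound 3 cannot be ranked, and only the cyano and methoxy pair is set apart among the three groups compared here. No measurement is available that accounts for this difference between cyano and methoxy.

From the compounds shown here alone, it remains open whether other groups on this carbon, such as an amine, a carboxylic acid or a longer chain like ethoxy, would fall within the same narrow span or move well outside it. Going by these compounds, it also remains open whether methoxy in place of cyano would give a step of similar size and direction on another carbon of this ring, since all three compounds vary at this one place.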